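The compounds below may be only part of what the source reports. "The series", "measured", "known", "first", "only" and "open" are said of these compounds alone.

Measured so far:
- compound 1 `COc1ccc(-c2cc3[nH]nc(N)c3c(=O)[nH]2)cc1`: 7%
- compound 2 `COc1ccc(-c2cc3c(c(N)nn3C)c(=O)[nH]2)cc1`: 16%
- compound 3 `Cc1cc2c(cn1)c(N)nn2C`: 9%

In an assay on isolated protein for inhibition of MAP kinase-activated protein kinase 5 (Homo sapiens), read by mobility shift assay, tested at 30 uM (a lower number here means less inhibition, a higher number more inhibition at the concentration tested (going by the name of the read-out)), compound 1 gives 7%, compound 2 gives 16% and compound 3 gives 9%; all three numbers lie within the scatter of one another. Within the data shown here, the one counted change in the set is hydrogen in place of methyl on an aromatic nitrogen, and it gave a number 9 percentage points lower from compound 2 to compound 1 (within the scatter). The difference between the core of compound 3 and the core of compound 2 is not broken down here.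

Compound 4 `Cc1cc2[nH]nc(N)c2cn1` is not yet measured. It carries the same change on the core of compound 3: hydrogen in place of methyl on an aromatic nitrogen. Since this change from compound 2 to compound 1 gave a number 9 percentage points lower from compound 2 to compound 1 (within the scatter), a step of similar size is expected, a number 3 percentage points lower from compound 3 to compound 4 (within the scatter), which rests on that single pair alone. Compound 4 is therefore estimated at 6%, expected between -4% and 16%.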

Compound 4, a percentage reported as inhibition, at one concentration (the size of the read-out at that concentration, not a potency): 13%
The estimate for compound 4 lay 7 percentage points below the measured number; low and high end bracket the measured number.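

In this assay, hydrogen in place of methyl on an aromatic nitrogen gives a number 4 percentage points higher from compound 3 to compound 4 (within the scatter), and set beside the step on the other core it reads: the same change on two cores in this assay, a number 9 percentage points lower (within the scatter) from compound 2 to compound 1 and a number 4 percentage points higher (within the scatter) from compound 3 to compound 4, 13 percentage points apart, within the scatter of two such steps. The two cores therefore show no separable difference in how this change behaves. That does not establish that the change acts alike on both cores: each core offers a single pair, and neither step lies beyond the scatter.

The compounds shown leave open what a longer chain such as ethyl on that aromatic nitrogen would give. Also open, going by these compounds, is what a carboxylic acid in place of the amino group would give on either core.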